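The source may report more compounds than this note shows. Statements on the series, on what has been measured and on what is new or still open speak of the compounds shown alone.

Measured in a functional assay on K562 cells (Homo sapiens) for antiproliferative activity, read by resazurin assay, with a stated time of 72 h; a higher number here means a weaker inhibitor of growth, a lower number a stronger inhibitor of growth:
- Compound 1 `O=C1C(N2CCCCC2)=NN(c2ccc(Cl)cc2)CN1c1ccccc1Cl`: > 50 ug/mL (a limit of the assay, not a number)
- Compound 2 `O=C1C(N2CCCC2)=NN(c2ccccc2)CN1c1ccccc1Cl`: 5.2 ug/mL
- Compound 3 `CN(C)C1=NN(c2ccc(Cl)cc2)CN(c2ccccc2Cl)C1=O`: 11 ug/mL

Only compound 2 and compound 3 have actual numbers in this assay. Compound 3 stands at the higher of the two, at 11 ug/mL, and the gap to compound 2 lies just beyond the usual scatter.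

Compound 4 `O=C1C(N2CCCC2)=NN(c2ccc(Cl)cc2)CN1c1ccccc1Cl` follows from compound 3 by one change, pyrrolidin-1-yl in place of dimethylamino on a carbon with a double bond to nitrogen.

Among the compounds with values here, one measured step bears on this place, an at least 4.5-fold lower number from compound 1 to compound 3 (0.65 log units; beyond the scatter), where dimethylamino replaced piperidin-1-yl. Read backwards, that step warns that a ring amine here may raise the number, but its ring is not the one entering now, and its size is known only against a limit. Compound 2 does carry pyrrolidin-1-yl and gives 5.2 ug/mL, although it has phenyl where compound 4 has 4-chlorophenyl. These two hints pull in opposite directions, so no step beyond the scatter is expected, with the risk lying towards weaker growth inhibition. The expected change is a 1.1-fold lower number from compound 3 to compound 4 (0.04 log units; within the scatter). For compound 4 the estimated value is 10 ug/mL, with an expected range from 4 ug/mL to 30 ug/mL.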

Compound 4, concentration for 50% growth inhibition: 8.6 ug/mL
For compound 4 the middle estimate is 1.2-fold (0.07 log units) above the measured one, within the range that was stated.
By their numbers in this assay, from the lowest: compounds 2, 4 and 3 (each within the scatter of the next, the first and the last beyond it). At a limit, above all of these: compound 1.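

In this assay, replacing dimethylamino with pyrrolidin-1-yl gives a 1.3-fold lower number from compound 3 to compound 4 (0.11 log units; within the scatter), so this place accepts a five-membered ring amine much as it accepts dimethylamino, and the earlier loss with piperidin-1-yl cannot be read as applying to every ring amine here. With the rest of the molecule unchanged, the two ring amines can now be compared directly, giving an at least 5.8-fold lower number from compound 1 to compound 4 (0.76 log units; beyond the scatter), though this sets only a bound on the size of the step: the limit of > 50 ug/mL in this assay, at which 1 of the 4 values shown sits.

With pyrrolidin-1-yl in place, chloro instead of hydrogen on the aromatic carbon gives a 1.7-fold higher number from compound 2 to compound 4 (0.22 log units; within the scatter), so this change does not separate the two compounds in this assay.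

The compounds shown leave open whether a smaller ring such as azetidin-1-yl, or a ring with a second hetero atom such as morpholin-4-yl, would fit this place as well as pyrrolidin-1-yl does. They also leave open whether the gap between piperidin-1-yl and pyrrolidin-1-yl would persist with phenyl in place of 4-chlorophenyl.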